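The source may report more compounds than this note shows. Statements on the series, on what has been measured and on what is new or still open speak of the compounds shown alone.

Working notes on the series, assay a functional assay on BT-549 cells (Homo sapiens) for inhibition, read by sulforhodamine B assay, with a stated time of 48 h, tested at 10 uM; on this read-out lower numbers stand for a stronger effect and higher numbers for a weaker effect at the one concentration tested.

Measured so far:
compound 1 `COc1cc(Cl)cc(-c2nn(-c3cccc(NC(=O)c4ccc(Cl)c(Cl)c4)c3)cc2-c2ccncc2)c1` gives 85.2%
compound 2 `O=C(Nc1cccc(-n2cc(-c3ccncc3)c(-c3cc(O)cc(Cl)c3)n2)c1)Nc1ccc(Cl)c(Cl)c1` gives 0.54%
compound 3 `COc1cc(Cl)cc(-c2nn(-c3cccc(NC(=O)Nc4ccc(Cl)c(C(F)(F)F)c4)c3)cc2-c2ccncc2)c1` gives 9.81%

Compound 3 stands second highest of the three numbers. Its nearest neighbour is compound 2, whose value lies within the usual scatter of that of compound 3, so no order between the two is claimed. Among the measured compounds shown here, the furthest is compound 1: the single-point step a number 75.4 percentage points lower from compound 1 to compound 3 (beyond the scatter) is beyond the scatter and is the only measured step in the set, and it changes both the linker on the carbonyl carbon and the substitution of the outer ring at once.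

The next compound is compound 4 `COc1cc(Cl)cc(-c2nn(-c3cccc(NC(=O)Nc4cccc(C(F)(F)F)c4)c3)cc2-c2ccncc2)c1`. It differs from compound 3 by hydrogen in place of chloro on an aromatic carbon. For the measured compounds named here, no measured pair isolates this change; the step from compound 1 to compound 3 does not separate the removal of a chloro from the other changes it carries, and compound 2 differs from compound 3 in two places. Given that, the expected step of a number 5.2 percentage points higher from compound 3 to compound 4 (within the scatter) is estimated as small, not beyond the scatter, in either direction. Compound 4 is thus expected to give about 15% in this assay, with a range from 2% to 40%.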

Compound 4, a percentage reported as activity, at one concentration (the size of the read-out at that concentration, not a potency): 12.9%
For compound 4 the middle estimate is 2.1 percentage points above the measured one; low and high end bracket the measured number.
By their numbers in this assay, from the lowest: compounds 2, 3 and 4 (each within the scatter of the next, the first and the last beyond it); then compound 1.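

In this assay, among the compounds shown here, the pair of compound 3 and compound 4 isolates the position ortho to a trifluoromethyl group and para to a large group for the first time: going from 4-chloro-3-(trifluoromethyl)phenyl to 3-(trifluoromethyl)phenyl gives a number 3.1 percentage points higher from compound 3 to compound 4 (within the scatter). At this single concentration, the chloro at this position is therefore not required for the low number seen with compound 3, and the large step of a number 72.3 percentage points lower from compound 1 to compound 4 (beyond the scatter) holds with hydrogen at this position, although that step still cannot separate the added amino from the trifluoromethyl group on the outer ring. No measurement on hand offers an explanation for either step.

Open, from the compounds shown here alone, is whether this position tolerates other groups, such as a nitrile or a dimethylamino group, and whether the trifluoromethyl group itself can be replaced by hydrogen with the chloro kept or removed. A read-out at one concentration also leaves open whether compound 3 and compound 4 would differ in potency across a range of concentrations.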